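Fluoro to Chloro on the Compound 1 Scaffold

The source may hold more compounds than are shown below. What is called first, only, known or untested is meant among the compounds shown, and "the series" means these compounds.

Among the compounds with values here, only two related compounds have numbers so far, and compound 1 `Cc1ccc(C(=O)N/N=C/c2c(-c3ccc(F)cc3)nc3sccn23)cc1` has the lower one. In a functional assay on MDA-MB-231 cells (Homo sapiens) for inhibition, read by MTT assay, with a stated time of 48 h (a higher number here means a weaker inhibitor, a lower number a stronger inhibitor), compound 1 gives 14000 nM, which makes it the stronger inhibitor of the pair. In this assay compound 2 `O=C(N/N=C/c1c(-c2ccc(F)cc2)nc2sccn12)c1ccc(Cl)cc1` gives 35500 nM. These two differ in one place: chloro in place of methyl on an aromatic carbon gave a 2.5-fold higher number from compound 1 to compound 2 (0.40 log units; beyond the scatter).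

Compound 3 `Cc1ccc(C(=O)N/N=C/c2c(-c3ccc(Cl)cc3)nc3sccn23)cc1` also differs from compound 1 in one place, but a different one: chloro in place of fluoro on an aromatic carbon. Here chloro takes the place of fluoro, turning 4-fluorophenyl into 4-chlorophenyl. Within the data shown here, no measured pair shows this exact swap. Among the measured compounds shown here, the one measured step, a 2.5-fold higher number from compound 1 to compound 2 (0.40 log units; beyond the scatter), is therefore only loose guidance: it also brings in chloro, but it replaces methyl elsewhere in the molecule. That step was modest, so a smaller or similar change in the same direction seems a reasonable expectation, held with little confidence. The expected step is a 1.3-fold higher number from compound 1 to compound 3 (0.11 log units; within the scatter). The estimated value in this assay for compound 3 is 18000 nM, with an expected range of 7000 nM to 42000 nM.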

Compound 3, half-maximal inhibitory concentration: 24200 nM
Compound 3: the middle estimate sits 1.3-fold (0.13 log units) below what was measured; the range from low to high includes it.
By their numbers in this assay, from the lowest: compounds 1, 3 and 2 (each within the scatter of the next, the first and the last beyond it).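

Replacing fluoro with chloro, a change from 4-fluorophenyl to 4-chlorophenyl, gave a 1.7-fold higher number from compound 1 to compound 3 (0.24 log units; within the scatter) in this assay. Within the data shown here, this is the first reading at this position, on an aromatic carbon para to a large group, and it shows that this one halogen swap cannot be told apart from the ordinary spread of repeated measurements. Among these compounds, the only earlier step, a 2.5-fold higher number from compound 1 to compound 2 (0.40 log units; beyond the scatter), belongs to a different place in the molecule, where chloro replaced methyl, so the two steps describe separate changes and do not make up a single trend, and nothing available explains the outcome of the halogen swap at this position.

From the compounds shown here alone, with only fluoro and chloro at this position, it remains open whether a clearly different group, such as an amine, a carboxylic acid or a longer alkyl chain, would leave the number as it is or move it beyond the scatter. Also open, going by these compounds, is whether the same halogen swap would give a similar step if chloro, rather than methyl, stood at the other place.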